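The source may report more compounds than this note shows. Statements on the series, on what has been measured and on what is new or still open speak of the compounds shown alone.

In a functional assay on MDA-MB-231 cells (Homo sapiens) for cytotoxicity, read by MTT assay, with a stated time of 72 h (a lower number here means a stronger inhibitor, a higher number a weaker inhibitor), three compounds sharing one core have been measured. Compound 1 `O=C1c2c[n+]([O-])c3ccccc3c2C(=O)c2c1c1ccccc1n2CCCCn1ccnc1` gives 210 nM, compound 2 `O=C1c2c[n+]([O-])c3ccccc3c2C(=O)c2c1c1ccccc1n2Cc1cn(CC(O)CO)nn1` gives 1290 nM, and compound 3 `CCCN1CCN(CCCCn2c3c(c4ccccc42)C(=O)c2c[n+]([O-])c4ccccc4c2C3=O)CC1` gives 2980 nM, which leaves compound 2 in the middle of the three. Compound 4 `O=C1c2c[n+]([O-])c3ccccc3c2C(=O)c2c1c1ccccc1n2Cc1cn([C@H]2C[C@H](O)[C@@H](CO)O2)nn1` differs from compound 2 in one group: 4-hydroxy-5-(hydroxymethyl)oxolan-2-yl in place of 2,3-dihydroxypropyl on an aromatic nitrogen. An open chain with no ring thus gives way to a group holding a five-membered non-aromatic ring, on the same aromatic nitrogen.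

Among the compounds with values here, no measured step touches this group alone. The closest guides exchange a larger piece of the molecule: a 6.1-fold higher number from compound 1 to compound 2 (0.79 log units; beyond the scatter) and a 2.3-fold higher number from compound 2 to compound 3 (0.36 log units; beyond the scatter), both modest, and a 14-fold higher number from compound 1 to compound 3 (1.15 log units; beyond the scatter), which was large. Since the exchange here is smaller than in a 2.3-fold higher number from compound 2 to compound 3 (0.36 log units; beyond the scatter), no step beyond the scatter is expected, in either direction. The estimated step is a 1.1-fold higher number from compound 2 to compound 4 (0.04 log units; within the scatter). The expected value for compound 4 is 1400 nM, with an estimated range from 500 nM to 3800 nM.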

Compound 4, half-maximal inhibitory concentration: 580 nM
Compound 4: the middle estimate sits 2.4-fold (0.38 log units) above what was measured, and the stated range covers the measured number.
By their numbers in this assay, from the lowest: compound 1; then compound 4; then compound 2; then compound 3.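

On an aromatic nitrogen of the five-membered aromatic ring with 3 nitrogen, swapping 2,3-dihydroxypropyl for 4-hydroxy-5-(hydroxymethyl)oxolan-2-yl gives a 2.2-fold lower number from compound 2 to compound 4 (0.35 log units; beyond the scatter) in this assay, the first step shown that changes this group alone. The entering group has 8 heavy atoms against 5 and adds a five-membered non-aromatic ring, yet the number falls, so a larger ring-bearing group is accepted here in this assay. No measured evidence explains this drop.

The ring, the extra oxygen and the 3 defined stereocentres all enter together, so the compounds shown cannot separate their contributions. From the compounds shown here alone, how an unsubstituted oxolan-2-yl group, or a 2-aminoethyl chain, would behave on this same nitrogen remains open.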